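Swapping benzylamino for pyrrolidine on a flavone-type chain

This account rests on a few compounds, and the source may have more. Where it says the series, first, only, none or still open, it means among the compounds named here.

Measured so far in a functional assay on A549 cells (Homo sapiens) for cytotoxicity, read by MTT assay, with a stated time of 48 h (a higher number here means a weaker inhibitor, a lower number a stronger inhibitor), for three compounds
- compound 1 `COc1c(OCCCCNCc2ccccc2)cc(O)c2c(=O)cc(-c3ccccc3)oc12` gives 4590 nM
- compound 2 `CC(C)NCCOc1c(O)cc(O)c2c(=O)cc(-c3ccccc3)oc12` gives "not determined" (no result reported)
- compound 3 `CC(CO)NCCOc1c(O)cc(O)c2c(=O)cc(-c3ccccc3)oc12` gives "not determined" (no result reported)

Only compound 1 has a number, so there is nothing yet to rank it against. Compounds 2 and 3 carry no result and say nothing about strength in either direction.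

The next compound to be tested is compound 4 `COc1c(OCCCCN2CCCC2)cc(O)c2c(=O)cc(-c3ccccc3)oc12` (it keeps the shared core of compound 1 and changes one group). That group is swapped as pyrrolidin-1-yl in place of benzylamino on a saturated chain carbon, four bonds along the chain from an oxygen on an aromatic ring (a six-membered aromatic ring leaves, and a five-membered non-aromatic ring enters).

Among the measured compounds shown here, no pair of measured compounds shows what a change at this place does in this assay and so the data give no direct guide to its size. For the measured compounds named here, the only anchor is compound 1 at 4590 nM and a large shift cannot be argued from one number. The estimated step of a 1.3-fold higher number from compound 1 to compound 4 (0.12 log units; within the scatter) is small, leaning slightly towards a weaker inhibitor but not expected to exceed the usual scatter of repeated measurements. Compound 4 is expected to come in near 6000 nM with an estimated range from 2000 nM to 20000 nM in this measurement.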

Compound 4, half-maximal inhibitory concentration: 1530 nM
Estimate against measurement, compound 4: 3.9-fold (0.59 log units) above; measured number outside the range, below it.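

Among the compounds shown here, this is the only measured change at this place, on a saturated chain carbon, four bonds along the chain from an oxygen on an aromatic ring, and in this assay pyrrolidin-1-yl in place of benzylamino gives a 3.0-fold lower number from compound 1 to compound 4 (0.48 log units; beyond the scatter). The group at this place therefore affects the read-out, and the six-membered aromatic ring and hydrogen-bond donor of benzylamino are not required for compound 4 to reach a lower number than compound 1. The swap alters the ring, its aromatic character and the donor count all at once, and no measurement at hand says which of these lies behind the shift.

The compounds shown leave open whether another ring amine, such as piperidin-1-yl or morpholin-4-yl, or an open-chain amine, such as diethylamino, would match pyrrolidin-1-yl at this place. Also open, as far as these compounds go, is how a shorter or longer chain would behave with pyrrolidin-1-yl at its end, a question that compounds 2 and 3 cannot help with, as neither has a result to read.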